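A few compounds are considered here, and "the series" means these few. Any claim that something is new, unique, unknown or untested is made for them only; others in the source may bear on it.

Three compounds have been measured in a functional assay (aorta) with Oryctolagus cuniculus as the target (a lower number here means tighter binding, a higher number weaker binding), so far:
- compound 1 `COc1cc(C(C)=O)ccc1OCCCN1CCC(C(c2ccccc2)c2ccc(F)cc2)CC1` at 6.31 nM
- compound 2 `COc1cc(C(C)=O)ccc1OCCCN1CCC(C(O)(c2ccc(F)c(F)c2)c2ccc(F)c(F)c2)CC1` at 2.51 nM
- compound 3 `COc1cc(C(=O)O)ccc1OCCCN1CCC(C(c2ccc(F)cc2)c2ccc(F)cc2)CC1` at 79.4 nM

Compound 3 has the highest number of the three, and its gap to each of the other two lies beyond the scatter. Compound 4 `N#Cc1ccc(OCCCN2CCC(C(c3ccc(F)cc3)c3ccc(F)cc3)CC2)cc1` has 4-cyanophenyl in place of 4-carboxy-2-methoxyphenyl on an oxygen on a saturated carbon, and the change amounts to 4-cyanophenyl in place of 4-carboxy-2-methoxyphenyl on an oxygen on a saturated carbon in all. Going by the values given here, no measured pair isolates this change. Only compound 3 carries the carboxy group, while compound 1 at 6.31 nM and compound 2 at 2.51 nM lack it and sit lower, so a fall beyond the scatter is expected in this assay here. The estimated step is a 5.3-fold lower number from compound 3 to compound 4 (0.72 log units; beyond the scatter) in that direction. Compound 4 is expected at 15 nM with an estimated range from 3 nM to 60 nM in this measurement.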

Compound 4, dissociation constant: 5.01 nM
Compound 4: middle estimate off by 3.0-fold (0.48 log units), on the high side; measured number inside the range.
By their numbers in this assay, from the lowest: compounds 2, 4 and 1 (each within the scatter of the next, the first and the last beyond it); then compound 3.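

In this assay, going by these compounds alone, 4-cyanophenyl in place of 4-carboxy-2-methoxyphenyl on an oxygen on a saturated carbon gives a 16-fold lower number from compound 3 to compound 4 (1.20 log units; beyond the scatter), the first step here between compounds differing in one place. It shows that this place accepts a ring bearing a nitrile and no hydrogen-bond donor, and that the group there can shift the number well beyond the scatter. Nothing measured explains the size of this step. As far as these compounds go, the change removes the carboxy and methoxy groups together, so their separate shares remain open. From the compounds shown here alone, how an amide or a tetrazole would read in the nitrile's place also remains open.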